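From methylsulfonyl to methyl on the shared core

The source may hold more compounds than are shown below. What is called first, only, known or untested is meant among the compounds shown, and "the series" means these compounds.

Compound 1 `O=C(CCCCCCC(=O)Nc1nc2ccccc2s1)NO` gives 5.71 ug/mL
Compound 2 `CS(=O)(=O)c1ccc2nc(NC(=O)CCCCCCC(=O)NO)sc2c1` gives 6.54 ug/mL
Compound 3 `CS(=O)(=O)c1ccc2nc(NC(=O)CCCCC(=O)NO)sc2c1` gives > 30 ug/mL (a limit)

All three were tested in a functional assay on NCI-H460 cells (Homo sapiens) for cytotoxicity (a higher number here means a weaker inhibitor, a lower number a stronger inhibitor), on the same footing. Compound 2 stands at 6.54 ug/mL in this assay and lies within the scatter of compound 1, so the two cannot be ranked. Compound 3 has only a limit (> 30 ug/mL) and not a number.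

Compound 4 `Cc1ccc2nc(NC(=O)CCCCCCC(=O)NO)sc2c1` differs from compound 2 in one place, methyl in place of methylsulfonyl on an aromatic carbon, and keeps the chain of compound 2. The measured step that bears on this change is a 1.1-fold higher number from compound 1 to compound 2 (0.06 log units; within the scatter) (methylsulfonyl in place of hydrogen on an aromatic carbon), which stayed within the scatter. The other step, an at least 4.5-fold higher number from compound 2 to compound 3 (0.66 log units; beyond the scatter) (a change in the chain), concerns a part that compound 4 leaves untouched, so its size is not carried over. No step beyond the scatter is therefore expected in this assay on going to methyl. The estimated change is a 1.1-fold lower number from compound 2 to compound 4 (0.04 log units; within the scatter) and would fall within the scatter. The estimate for compound 4 is 6 ug/mL with an expected range from 3 ug/mL to 12 ug/mL in this measurement.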

Compound 4, half-maximal inhibitory concentration: 0.84 ug/mL
Estimate against measurement, compound 4: 7.1-fold (0.85 log units) above, and the stated range ends above it.
By their numbers in this assay, from the lowest: compound 4; then compounds 1 and 2 (each within the scatter of the next). At a limit, above all of these: compound 3.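

In this assay, methyl on this aromatic carbon of the six-membered aromatic ring gives a 7.8-fold lower number from compound 2 to compound 4 (0.89 log units; beyond the scatter) and, measured against the unsubstituted core on the same chain, a 6.8-fold lower number from compound 1 to compound 4 (0.83 log units; beyond the scatter) as well, so compound 4 is the strongest inhibitor of the compounds shown. Within the data shown here, the earlier pair gave no sign of this, since methylsulfonyl in place of hydrogen had stayed within the scatter, and this position could have seemed indifferent to what it carries; methyl is the one group here that moves the number beyond the scatter, and it does so against both hydrogen and methylsulfonyl. Nothing measured here bears on why methyl parts from the other two groups.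

From the compounds shown here alone, whether ethyl, methoxy or a chlorine atom on the same aromatic carbon would follow methyl, or stay with hydrogen and methylsulfonyl, remains open. Also open, going by these compounds, is whether methyl would have the same effect on the shorter chain, since compound 3 has > 30 ug/mL as a limit and not a number.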